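Swapping methyl for methoxy on compound 2

The source may report more compounds than this note shows. Statements on the series, on what has been measured and on what is new or still open speak of the compounds shown alone.

In a functional assay on HL-60 cells (Homo sapiens) for inhibition, read by CCK-8 assay, with a stated time of 48 h, tested at 20 uM (on this read-out lower numbers stand for less inhibition of growth and higher numbers for more inhibition of growth at the one concentration tested), compound 1 (`COc1ccc(Cc2nnc(NC(=O)/C(C#N)=C/c3ccccc3OS(=O)(=O)c3ccc(OC)cc3)s2)cc1`) gives 100%, while compound 2 (`Cc1ccc(Cc2nnc(NC(=O)/C(C#N)=C/c3ccccc3OS(=O)(=O)c3ccc(C)cc3)s2)cc1`) gives 17%. Compound 2 therefore holds the lower of the two numbers, and the gap lies beyond the scatter. Compound 3 (`COc1ccc(S(=O)(=O)Oc2ccccc2/C=C(\C#N)C(=O)Nc2nnc(Cc3ccc(C)cc3)s2)cc1`) has not yet been measured. It differs from compound 2 in one place: methoxy in place of methyl on an aromatic carbon, para to a large group, so that (4-methylphenyl)sulfonyl becomes (4-methoxyphenyl)sulfonyl (methoxy in place of methyl on an aromatic carbon). Compound 1 carries the same (4-methoxyphenyl)sulfonyl group and gives 100%, but it also differs from compound 2 elsewhere, so only part of that gap is expected here. In this assay, the expected change is a number 38 percentage points higher from compound 2 to compound 3 (beyond the scatter), upward and beyond the scatter, though quite uncertain. The estimate for compound 3 is 55%, with an expected range from 20% to 95%.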

Compound 3, percent growth inhibition at one concentration: 100%
Estimate against measurement, compound 3: 45 percentage points below; measured number above the stated range.
By their numbers in this assay, from the lowest: compound 2; then compounds 1 and 3 (each within the scatter of the next).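

Placing methoxy instead of methyl on the aromatic carbon of the (4-methylphenyl)sulfonyl group gives a number 83 percentage points higher from compound 2 to compound 3 (beyond the scatter) in this assay, so this one change is enough to produce a large gain in growth inhibition. The same kind of swap at the other aromatic ring, with the (4-methoxyphenyl)sulfonyl group in place, gives no change at the digits printed from compound 1 to compound 3 (within the scatter), so among these three compounds only the sulfonyl side shows an effect. Nothing here explains why this position responds so strongly.

Testing at one concentration gives no way to tell compound 1 and compound 3 apart, so any difference between them at lower concentrations remains unknown. From the compounds shown here alone, it also remains open whether a hydroxy group, a chlorine atom or an amine at this position would match methoxy, and whether methoxy on the other ring alone would raise the number from compound 2.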